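From chloro to bromo on a weakly active compound

A few compounds are considered here, and "the series" means these few. Any claim that something is new, unique, unknown or untested is made for them only; others in the source may bear on it.

Measured in a functional assay on Hs 683 cells (Homo sapiens) for cytotoxicity, read by MTT assay, with a stated time of 72 h; on this read-out lower numbers stand for stronger inhibition and higher numbers for weaker inhibition
Compound 1 `CSc1nc(Cl)c(C(=O)c2ccccc2)s1` gives > 100000 nM (a limit)
Compound 2 `CSc1nc(Br)c(C(=O)c2ccccc2)s1` gives > 100000 nM (a limit)
Compound 3 `O=C(c1ccccc1)c1sc(N2CCCC2)nc1Cl` gives 44000 nM (a number)
Compound 4 `O=C(c1ccccc1)c1sc(N2CCCC2)nc1Br` is not yet measured

Only compound 3 has a true number here, 44000 nM in this assay. The other two values are limits. The move to compound 4 is a small swap: bromo in place of chloro on an aromatic carbon. It places bromo in place of chloro on an aromatic carbon, next to the ring nitrogen.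

The same swap appears as a step that the two limits leave unreadable from compound 1 to compound 2, so it offers no size to borrow. The other measured step, an at least 2.2-fold lower number from compound 1 to compound 3 (0.35 log units; beyond the scatter), came from pyrrolidin-1-yl in place of methylsulfanyl, a change not made here. With no readable size for this swap, no step beyond the usual scatter is expected in this assay, and the estimate stays close to the value of compound 3.

The expected outcome is a 1.1-fold lower number from compound 3 to compound 4 (0.04 log units; within the scatter). The estimated value for compound 4 is 40000 nM, with an expected range from 18000 nM to 90000 nM.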

Compound 4, half-maximal inhibitory concentration: > 100000 nM
Compound 4 ended at the assay's limit (the forecaster's own chance of this, stated with the estimate: 15%); middle value at least 2.5-fold (0.39 log units) away from the limit.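

In this assay, bromo in place of chloro on this aromatic carbon, next to the ring nitrogen, now has a readable size, with an at least 2.2-fold higher number from compound 3 to compound 4 (0.35 log units; beyond the scatter). So with pyrrolidin-1-yl in the shared core, the choice of halogen at this position matters, which the methylsulfanyl pair, compound 1 and compound 2, could not show. On these data alone, the full size of this step stays unknown, and the steps between pairs of limits cannot be read, as most of the set sits at one ceiling: the limit of > 100000 nM in this assay, at which 3 of the 4 values shown sit.

Still open, as far as these compounds go, is whether fluoro, a methyl group or a small amine on this carbon would give a lower number than compound 3 at 44000 nM. Also open, from the compounds shown here alone, is whether morpholin-4-yl or a longer amine chain in place of pyrrolidin-1-yl would keep a measurable value with bromo present.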